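N-Methylation of the ring amine in a 5-HT6 sulfonyl series

This account rests on a few compounds, and the source may have more. Where it says the series, first, only, none or still open, it means among the compounds named here.

Measured so far:
compound 1 `O=S(=O)(c1ccc(F)cc1)c1cn(C2CCNC2)c2ncccc12` — 8.5 nM
compound 2 `CN1CCC(n2cc(S(=O)(=O)c3ccc(F)cc3)c3cccnc32)C1` — 5 nM
compound 3 `O=S(=O)(c1cccc(F)c1)c1cn(C2CCCNC2)c2ncccc12` — 2.4 nM

Compounds 1, 2 and 3 were tested in an assay on HeLa cells for displacement of a labelled ligand from 5-hydroxytryptamine receptor 6 (Homo sapiens); a higher number here means a weaker inhibitor, a lower number a stronger inhibitor. Compound 1 `O=S(=O)(c1ccc(F)cc1)c1cn(C2CCNC2)c2ncccc12` gives 8.5 nM, and compound 2 `CN1CCC(n2cc(S(=O)(=O)c3ccc(F)cc3)c3cccnc32)C1` gives 5 nM. Compound 2 differs from compound 1 by methyl in place of hydrogen on an amine nitrogen in a ring, and that step is a 1.7-fold lower number from compound 1 to compound 2 (0.23 log units; within the scatter). Compound 3 `O=S(=O)(c1cccc(F)c1)c1cn(C2CCCNC2)c2ncccc12` gives 2.4 nM, the lowest of the three numbers; the difference between the core of compound 3 and the core of compound 1 is not broken down here.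

Compound 4 `CN1CCCC(n2cc(S(=O)(=O)c3cccc(F)c3)c3cccnc32)C1` has not yet been measured in this assay. It differs from compound 3 by methyl in place of hydrogen on an amine nitrogen in a ring. Among the measured compounds shown here, this is the same kind of change as the one from compound 1 to compound 2, but the place is not the same: there the amine nitrogen sits in a five-membered non-aromatic ring with one nitrogen, here in a six-membered non-aromatic ring with one nitrogen. Because the earlier step was a 1.7-fold lower number from compound 1 to compound 2 (0.23 log units; within the scatter), only a small step is expected for compound 4, estimated at a 1.6-fold lower number from compound 3 to compound 4 (0.20 log units; within the scatter). Compound 4 is therefore expected to give about 1.5 nM in this assay, with a range of 0.6 nM to 4 nM.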

Compound 4, inhibition constant: 4.7 nM
For compound 4 the middle estimate is 3.1-fold (0.50 log units) below the measured one; measured number above the stated range.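

In this assay, methyl in place of hydrogen on the amine nitrogen gives a 2.0-fold higher number from compound 3 to compound 4 (0.29 log units; within the scatter), so on the core of compound 3 this step, like the earlier one, lies within the scatter. Set side by side, however, the two steps differ in direction, and their gap shows that the change does not carry over from one core to the other as a single value: the same change on two cores in this assay, a 1.7-fold lower number (0.23 log units; within the scatter) from compound 1 to compound 2 and a 2.0-fold higher number (0.29 log units; within the scatter) from compound 3 to compound 4, 3.3-fold (0.52 log units) apart, beyond the scatter of two such steps

What this does not show is which part of the core sets the gap: the cores of compound 1 and compound 3 differ in more than one place, and each step rests on a single pair. The compounds shown leave open whether the methyl step would keep its size on a core that pairs the five-membered ring of compound 1 with the aryl sulfonyl group of compound 3. They also leave open how either core would respond to an ethyl or acetyl group on the same nitrogen.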